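Flipping one ring stereocentre on the fluorocyclopropyl amide

The compounds below may be only part of what the source reports. "The series", "measured", "known", "first", "only" and "open" are said of these compounds alone.

Measured compounds:
compound 1 `CC(=O)N1CC2CC(C1)N2`, in an assay on SH-EP1 cells for agonist activity at Neuronal acetylcholine receptor; alpha4/beta2 (Homo sapiens), read by FLIPR and calcium flux (a lower number here means a smaller maximal response, a higher number a larger maximal response), compound 1 gives 95%
compound 2 `CCC(=O)N1CC2CC(C1)N2`, compound 2 gives 110%
compound 3 `O=C([C@@H]1C[C@@H]1F)N1CC2CC(C1)N2`, compound 3 gives 110%

Compound 3 stands level with compound 2 at the digits shown, the two together being the highest of the three numbers; its nearest neighbour is compound 2, with no change at the digits printed from compound 2 to compound 3 (within the scatter), and its furthest is compound 1, with a number 15 percentage points higher from compound 1 to compound 3 (beyond the scatter).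

Compound 4 `O=C([C@H]1C[C@@H]1F)N1CC2CC(C1)N2` is the unmeasured one. Its difference from compound 3 is the two compounds have the same atoms and bonds; at least one stereo element is drawn with a configuration in one of them and without one in the other: 1 of 4 stereo elements differ; a stereocentre at a saturated ring carbon is drawn S in compound 3 and R in compound 4.

Among the measured compounds shown here, none of the measured steps bears directly on this change. The steps of a number 15 percentage points higher from compound 1 to compound 2 (beyond the scatter) and a number 15 percentage points higher from compound 1 to compound 3 (beyond the scatter) swap one acyl group for another and say nothing about the arrangement at a stereocentre, and the step of no change at the digits printed from compound 2 to compound 3 (within the scatter) is within the scatter. With no guide from the measured compounds, the expected step is one within the scatter, in no particular direction: a number 5 percentage points lower from compound 3 to compound 4 (within the scatter). Compound 4 is therefore estimated at 105%, ranging from 85% to 125%.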

Compound 4, largest response reached (Emax), in percent of the reference or control that the assay uses: 100%
For compound 4 the middle estimate is 5 percentage points above the measured one; the range from low to high includes it.
By their numbers in this assay, from the lowest: compounds 1, 4, 2 and 3 (each within the scatter of the next, the first and the last beyond it).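

Flipping the stereocentre at the saturated ring carbon from S to R gives a number 10 percentage points lower from compound 3 to compound 4 (within the scatter) in this assay, the first step here that touches spatial arrangement rather than the acyl group, and it does not stand out from the scatter. The flipped compound also blurs an earlier contrast: the 2-fluorocyclopropyl amide stood clear of the methyl amide as compound 3, yet the same swap now gives a number 5 percentage points higher from compound 1 to compound 4 (within the scatter), while exchanging ethyl for this group gives a number 10 percentage points lower from compound 2 to compound 4 (within the scatter). The only structural difference on record between the two isomers is this: the fact that one of compounds 3 and 4 is drawn with a defined configuration and the other without, at the place where they differ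

The compounds shown leave open whether changing the other stereocentre of the fluorocyclopropyl ring would give a similar result. They also leave open how a plain cyclopropyl group without fluorine, or a longer chain on the carbonyl, would compare.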